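A few compounds are considered here, and "the series" means these few. Any claim that something is new, unique, unknown or untested is made for them only; others in the source may bear on it.

Compound 1, `Nc1nc(N)c2c(-c3ccsc3)cn([C@@H]3O[C@H](CO)[C@@H](O)[C@H]3O)c2n1`.
Compound 2, `Cc1nc(N)c2c(-c3ccsc3)cn([C@@H]3O[C@H](CO)[C@@H](O)[C@H]3O)c2n1`.
Compound 3, `COc1ncnc2c1c(-c1cc3ccccc3o1)cn2[C@@H]1O[C@H](CO)[C@@H](O)[C@H]1O`.

Compound 1 is the starting point. In a functional assay on CEM-DNR-bulk cells (Homo sapiens), read by MTT assay, with a stated time of 72 h (a lower number here means a stronger inhibitor, a higher number a weaker inhibitor), compound 1 gives > 20000 nM, which is a limit of the assay and not a number. Compound 2 likewise gives > 20000 nM, again a limit. Among the measured compounds shown here, compound 3 gives 10800 nM, the only real number among the three. Compound 1 therefore stands at the limit, as does one other value shown. The step from compound 1 to compound 2 is a step that the two limits leave unreadable from compound 1 to compound 2, so it says nothing about size. Compound 4 `Nc1nc(N)c2c(-c3ccoc3)cn([C@@H]3O[C@H](CO)[C@@H](O)[C@H]3O)c2n1` differs from compound 1 by furan-3-yl in place of thiophen-3-yl on an aromatic carbon. For the measured compounds named here, no measured step exchanges these two rings, and the one measured step is unreadable because of the limit of > 20000 nM in this assay, at which 2 of the 3 values shown sit. Compound 4 is therefore expected to stay at or near the limit, estimated at 30000 nM (range 10000 nM to 100000 nM). That estimate would mean a step that the limit leaves unreadable from compound 1 to compound 4.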

Compound 4, half-maximal inhibitory concentration: > 20000 nM
Compound 4: a limit, no number (the forecaster's own chance of this, stated with the estimate: 80%); the middle value does not contradict the limit.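

Compound 4 and compound 1 cannot be compared in size, because both sit at a limit of the assay rather than at a number: the limit of > 20000 nM in this assay, at which 3 of the 4 values shown sit. From the compounds shown here alone, whether furan-3-yl and thiophen-3-yl differ at all on the shared core stays open.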